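Methoxymethyl removal from compound 2

A few compounds are considered here, and "the series" means these few. Any claim that something is new, unique, unknown or untested is made for them only; others in the source may bear on it.

Measured in a functional assay on MCF7 cells (Homo sapiens) for antiproliferative activity, read by MTT assay; a lower number here means a stronger inhibitor, a higher number a weaker inhibitor:
- compound 1 `CCCC/C=C\CCCCCCCCCc1cc(=O)c2c(O)cc(OCOC)cc2o1`: > 67200 nM, a limit
- compound 2 `CCCC/C=C\CCCCCCCCCc1cc(=O)c2c(O)c(C)c(OCOC)cc2o1`: > 67200 nM, a limit
- compound 3 `CC/C=C\C/C=C\C/C=C\CCCCCCCc1cc(=O)c2c(O)c(C)c(OCOC)cc2o1`: 17500 nM

Compound 2 is known only through (the limit of > 67200 nM in this assay, at which 2 of the 3 values shown sit), so the step starts from a limit and not from a number.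

Compound 4 `CCCC/C=C\CCCCCCCCCc1cc(=O)c2c(O)c(C)c(O)cc2o1` differs from compound 2 as follows: hydrogen in place of methoxymethyl on an oxygen on an aromatic ring. This is methoxymethoxy to hydroxy.

Among the compounds with values here, no measured step involves this oxygen. The methyl change gives a step that the two limits leave unreadable from compound 1 to compound 2. The chain change gives an at least 3.8-fold lower number from compound 2 to compound 3 (0.58 log units; beyond the scatter). Neither gives a direct size for the present change, so the expectation is weakly founded. Within the data shown here, the only number is that of compound 3 at 17500 nM, which shows that a readable value is possible with this core. A modest move to a lower number is expected in this assay, though compound 4 may also remain at the limit. The estimated step is an at least 1.6-fold lower number from compound 2 to compound 4 (0.22 log units; that floor lies within the scatter). For compound 4 the estimated value is 40000 nM, with an expected range of 15000 nM to 100000 nM.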

Compound 4, half-maximal inhibitory concentration: 43200 nM
For compound 4 the middle estimate is 1.1-fold (0.03 log units) below the measured one; the measured number falls inside the stated range.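

In this assay compound 4, with hydroxy in place of methoxymethoxy, gives 43200 nM, so the chain shared with compounds 1 and 2 can yield a number rather than a limit once this oxygen carries hydrogen. The change of hydrogen in place of methoxymethyl on an oxygen on an aromatic ring reads as an at least 1.5-fold lower number from compound 2 to compound 4 (0.19 log units; that floor lies within the scatter). That figure is a floor and not a size, because one end of the step is known only as a limit: the limit of > 67200 nM in this assay, at which 2 of the 4 values shown sit.

Open, as far as these compounds go, is whether the same change on the chain of compound 3 would shift its number, and by how much. Also open, from the compounds shown here alone, is how this oxygen would read when carrying a methyl or an acetyl group instead of hydrogen.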